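This account rests on a few compounds, and the source may have more. Where it says the series, first, only, none or still open, it means among the compounds named here.

Three compounds sharing one core were tested in a functional assay on Huh-7 cells (Homo sapiens) for antiproliferative activity, read by CCK-8 assay, with a stated time of 72 h; a lower number here means a stronger inhibitor of growth, a higher number a weaker inhibitor of growth. Compound 1 `CCCNC(=O)c1ccc2c(ccn2-c2ncc3c(n2)N(c2ccn(C)n2)C(CC)C(=O)N3C)c1` gives 7280 nM in this assay, and compound 3 `CCCCNC(=O)c1ccc2c(ccn2-c2ncc3c(n2)N(c2ccn(C)n2)C(CC)C(=O)N3C)c1` gives 8670 nM. The change between them, (methyl in place of hydrogen on a saturated chain carbon, three bonds along the chain from an amide-type nitrogen), made the step of a 1.2-fold higher number from compound 1 to compound 3 (0.08 log units; within the scatter). Compound 2 `CCCNC(=O)c1ccc2c(ccn2-c2ncc3c(n2)N(C2CCCC2)[C@H](CC)C(=O)N3C)c1` carries a different core; how its core differs from that of compound 1 is not broken down here. In this assay compound 2 gives 689 nM, the lowest of the three numbers and beyond the scatter from both compound 1 and compound 3.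

Compound 4 `CCCCNC(=O)c1ccc2c(ccn2-c2ncc3c(n2)N(C2CCCC2)[C@H](CC)C(=O)N3C)c1` is not yet measured. It differs from compound 2 by methyl in place of hydrogen on a saturated chain carbon, three bonds along the chain from an amide-type nitrogen, the same change that led from compound 1 to compound 3. Because that earlier step was a 1.2-fold higher number from compound 1 to compound 3 (0.08 log units; within the scatter), the expected step here is a 1.2-fold higher number from compound 2 to compound 4 (0.08 log units; within the scatter), a movement expected to stay within the scatter, though the change is seen only once and on the other core. On this basis compound 4 is estimated at 830 nM in this assay, expected to fall between 350 nM and 2000 nM.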

Compound 4, concentration for 50% growth inhibition: 683 nM
The estimate for compound 4 lay 1.2-fold (0.08 log units) above the measured number; measured number inside the range.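

In this assay, the methyl that extends the propyl chain on the amide nitrogen to a butyl chain gave a 1.0-fold lower number from compound 2 to compound 4 (0.00 log units; within the scatter) on the core of compound 2. Set beside the earlier step, the change reads the same on both cores: the same change on two cores in this assay, a 1.2-fold higher number (0.08 log units; within the scatter) from compound 1 to compound 3 and a 1.0-fold lower number (0.00 log units; within the scatter) from compound 2 to compound 4, 1.2-fold (0.08 log units) apart, within the scatter of two such steps. For the compounds shown here, this shows that, for these two pairs, the step from propyl to butyl carried over from one core to the other and left the number within the usual scatter each time, but it rests on only two pairs, one change and one assay, so it does not show that the same would hold on any other core or explain why the number holds steady.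

The compounds shown leave open whether a longer chain such as pentyl, or a branched chain such as isopropyl, would also leave the number within the scatter on these two cores. They also leave open what a chain ending in an amine or a carboxylic acid would do.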